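Amide cap variation from compound 1

This account rests on a few compounds, and the source may have more. Where it says the series, first, only, none or still open, it means among the compounds named here.

Measured so far:
compound 1, `O=C(CCCCCCNC(=O)C(O)(O)C(F)(F)F)Nc1nccs1`: 10800 nM
compound 2, `NC(=O)C(=O)NCCCCC(=O)Nc1ccccc1`: > 100000 nM
compound 3, `O=C(CCCCCCNC(=O)C(O)(O)C(F)(F)F)Nc1nc(-c2ccccc2)c(-c2ccccc2)s1`: 29900 nM

In a functional assay on HCT-116 cells (Homo sapiens) for inhibition, read by colorimetric assay, with a stated time of 3 days (on this read-out lower numbers stand for stronger inhibition and higher numbers for weaker inhibition), compound 1 gives 10800 nM, the lowest of the two numbers measured. Compound 3 gives 29900 nM, a higher number, and the gap lies beyond the scatter. For compound 2 the read-out is a limit and not a number: > 100000 nM, as stated in the limit of > 100000 nM in this assay, at which 1 of the 3 values shown sits. Compound 4, `CC(=O)c1ccc(NC(=O)CCCCCCNC(=O)C(O)(O)C(F)(F)F)cc1`, is not yet measured and differs from compound 1 in one place: 4-acetylphenyl in place of 1,3-thiazol-2-yl on an amide-type nitrogen. Going by the values given here, no measured pair isolates this change, so the data give no step size for it. The step is expected to be modest and toward a weaker number, a 1.5-fold higher number from compound 1 to compound 4 (0.17 log units; within the scatter). Compound 4 is estimated at 16000 nM, within a range from 4000 nM to 65000 nM.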

Compound 4, half-maximal inhibitory concentration: 12100 nM
Beside the measured number, compound 4's estimate is 1.3-fold (0.12 log units) above it; the range from low to high includes it.
By their numbers in this assay, from the lowest: compounds 1 and 4 (each within the scatter of the next); then compound 3. At a limit, above all of these: compound 2.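

Going by these compounds alone, this is the first readable step at this position: placing 4-acetylphenyl where 1,3-thiazol-2-yl stood on the amide-type nitrogen gives a 1.1-fold higher number from compound 1 to compound 4 (0.05 log units; within the scatter) in this assay. A six-membered aromatic ring of carbon only, carrying a larger group, therefore reads the same here as the five-membered aromatic ring with hetero atoms. Nothing shown gives a cause for this step.

Open, on these data alone, is whether an amine or a carboxylic acid in place of the acetyl group would read the same. As far as these compounds go, the effect of a longer chain also remains open.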